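Acetylazetidine for acetylmorpholine on the amide chain

The source may hold more compounds than are shown below. What is called first, only, known or untested is meant among the compounds shown, and "the series" means these compounds.

In an ADME assay on microsomes from liver (Mus musculus, strain CD-1) for metabolic stability, read by LC-MS, tested at 2 uM (a higher number here means that the compound lasts longer, a lower number that the compound disappears faster), compound 1 `CNC(=O)c1ccncc1Nc1cc(-c2ccc3ccn(C)c3c2)c2nccnc2c1` gives 0.45 h and compound 3 `CC(=O)N1CCOC(CNC(=O)c2ccncc2Nc2cc(-c3ccc4ccn(C)c4c3)c3nccnc3c2)C1` gives 0.217 h. Compound 2 `Cn1ccc2ccc(-c3cc(Nc4cnccc4C(=O)NCC4COCCN4)cc4nccnc34)cc21` reads > 1 h, which is a limit of the assay and not a number. Compound 3 has the lower of the two numbers, with a 2.1-fold lower number from compound 1 to compound 3 (0.32 log units; beyond the scatter).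

In compound 4 `CC(=O)N1CC(CNC(=O)c2ccncc2Nc2cc(-c3ccc4ccn(C)c4c3)c3nccnc3c2)C1`, 1-acetylazetidin-3-yl stands in place of 4-acetylmorpholin-2-yl on a saturated chain carbon bound to an amide-type nitrogen (1-acetylazetidin-3-yl in place of 4-acetylmorpholin-2-yl on a saturated chain carbon bound to an amide-type nitrogen).

The measured steps at this place are all modest or at least modest, and they run both ways: an at least 2.2-fold higher number from compound 1 to compound 2 (0.34 log units; beyond the scatter) and an at least 4.6-fold lower number from compound 2 to compound 3 (0.66 log units; beyond the scatter). Going by the values given here, no measured step swaps one acetylated ring for another. Compound 4 keeps the acetylated ring of compound 3, so the expectation stays close to what compound 3 gives, 0.217 h, with a slight lean towards compound 1. The expected change is a 1.3-fold higher number from compound 3 to compound 4 (0.11 log units; within the scatter), and no clear step beyond the scatter is expected. For compound 4 the estimate is 0.28 h, with an expected range of 0.14 h to 0.6 h.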

Compound 4, half-life: > 1 h
Compound 4 was reported as a limit (the forecaster's own chance of this, stated with the estimate: 5%); middle value at least 3.5-fold (0.55 log units) away from the limit.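

In this assay, 1-acetylazetidin-3-yl in place of 4-acetylmorpholin-2-yl gives an at least 4.6-fold higher number from compound 3 to compound 4 (0.66 log units; beyond the scatter), so an acetylated ring on this saturated chain carbon bound to an amide-type nitrogen need not lower the number. Set against hydrogen at the same place, the new group gives an at least 2.2-fold higher number from compound 1 to compound 4 (0.34 log units; beyond the scatter), which runs in the same direction as morpholin-3-yl with an at least 2.2-fold higher number from compound 1 to compound 2 (0.34 log units; beyond the scatter), while 4-acetylmorpholin-2-yl runs the other way. Compound 2 and compound 4 each read as a limit of the assay and not as a number, and the step between them cannot be read: the limit of > 1 h in this assay, at which 2 of the 4 values shown sit.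

The two acetylated groups differ in both ring size and ring oxygen, and the compounds shown do not separate these two changes. A 1-acetylpyrrolidin-3-yl or a free azetidine amine at this place would bear on that question.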